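The compounds below may be only part of what the source reports. "The series", "measured", "known", "first", "only" and "open" are said of these compounds alone.

Measured compounds:
- compound 1 `Cn1cc(-c2ncc(C#N)c(N3CCN(c4cccc(F)c4)C(C)(C)C3)n2)cn1`: 3.6
- compound 2 `N#Cc1cnc(-c2ccccc2)nc1N1C[C@@H]2C[C@H]1CN2c1cccc(F)c1`: 4.5
- compound 3 `C[C@@H]1C[C@H]1C(=O)N1CCN(c2nc(-c3cnn(C)c3)ncc2C#N)C[C@H]1C`: 1.9

In a physicochemical assay for lipophilicity, read by HPLC (on this read-out lower numbers stand for lower lipophilicity and higher numbers for higher lipophilicity), compound 2 stands highest of the three numbers. Compound 1 comes nearest, at a value lower by more than the usual scatter, and compound 3 lies furthest away, again by more than the scatter. Going by the values given here, the three compounds differ from one another in more than one place, so no single-change step between measured compounds is available for this assay, and the expectation for compound 4 rests on the structural change alone.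

Compound 4 `N#Cc1cnc(N2Cc3cn[nH]c3C2)nc1N1C[C@@H]2C[C@H]1CN2c1cccc(F)c1` differs from compound 2 in one place: a group of 8 heavy atoms (5 carbon, 3 nitrogen; one five-membered non-aromatic ring with 1 hetero atom, one five-membered aromatic ring with 2 hetero atoms) in place of a group of 6 heavy atoms (6 carbon; one six-membered aromatic ring of carbon only), on an aromatic carbon. The leaving group counts no hydrogen-bond donor and no acceptor, while the entering group counts one hydrogen-bond donor and two acceptors and carries three nitrogen atoms in place of carbon only. For this assay the step is expected to be a fall, well beyond the scatter rather than within it. Compound 4 is accordingly expected to give 2.8 in this assay, with a likely range from 2.1 to 3.5. The step that this estimate implies, a number 1.70 log units lower from compound 2 to compound 4 (beyond the scatter), is expected to be a clear decrease in lipophilicity, leaving compound 4 below compound 1 as well.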

Compound 4, distribution coefficient: 2.9
Estimate against measurement, compound 4: 0.10 log units below; measured number inside the range.
By their numbers in this assay, from the lowest: compound 3; then compound 4; then compound 1; then compound 2.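

In this assay, going by these compounds alone, the exchange of phenyl for the entering group, with its one five-membered non-aromatic ring and one five-membered aromatic ring, gives a number 1.60 log units lower from compound 2 to compound 4 (beyond the scatter) as the first single-change step. Within the data shown here, it places this effect on the aromatic carbon between two ring nitrogen atoms, para to a cyano group, with the rest of compound 2 unchanged, which the earlier compounds could not do because they differ from one another in more than one place. Nothing available bears on the reason for this step.

The step covers the exchange as a whole, so it does not separate the departure of phenyl from the arrival of either ring, the hydrogen-bond donor or the three nitrogen atoms of the entering group. Also open, on these data alone, is where a morpholine, a simple amine or a carboxylic acid at this same carbon would fall in this assay relative to compound 2 and compound 4, and whether the same exchange would give a step of similar size on the core of compound 1 or compound 3.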